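From furan-2-yl to 1-methyl-1H-pyrazol-5-yl on compound 3

The source may hold more compounds than are shown below. What is called first, only, known or untested is meant among the compounds shown, and "the series" means these compounds.

In a functional assay on PC-3 cells (Homo sapiens) for antiproliferative activity, read by CCK-8 assay, with a stated time of 6 days (a lower number here means a stronger inhibitor, a higher number a weaker inhibitor), compound 1 (`Cc1noc(C)c1-c1cccc(Oc2ccc(C#N)c(C(F)(F)F)c2)c1`) gives "not determined" (no result reported). Compound 2 (`N#Cc1ccc(N2CCc3cc(-c4cncnc4)ccc32)cc1C(F)(F)F`) likewise gives "not determined" (no result reported). Among the measured compounds shown here, compound 3 (`CCN(c1ccc(C#N)c(Cl)c1)c1cc(-c2ccco2)ccc1C`) gives > 30000 nM, which is a limit and not a number, and it is the only reading that the set offers. Compound 4 (`CCN(c1ccc(C#N)c(Cl)c1)c1cc(-c2ccnn2C)ccc1C`) carries 1-methyl-1H-pyrazol-5-yl in place of furan-2-yl on an aromatic carbon. For the measured compounds named here, no measured step is available to size this change, so nothing beyond the scatter is expected in this assay, in either direction. The estimated change is a number no higher from compound 3 to compound 4 (the limit leaves the size open). The expected reading for compound 4 is 30000 nM, with an estimated range of 10000 nM to 60000 nM, and a report as a limit alone is the likeliest outcome.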

Compound 4, half-maximal inhibitory concentration: 7290 nM
Estimate against measurement, compound 4: 4.1-fold (0.61 log units) above; the whole stated range lies above it.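

On the aromatic carbon para to a methyl group, the series responds to the ring that is attached: in this assay, 1-methyl-1H-pyrazol-5-yl in place of furan-2-yl gives an at least 4.1-fold lower number from compound 3 to compound 4 (0.61 log units; beyond the scatter). Compound 4 gives a number here, but the full size of the step stays open, because the reading for compound 3 is a limit and not a number: the limit of > 30000 nM in this assay, at which 1 of the 4 values shown sits.

The compounds shown do not separate the contribution of the ring nitrogens from that of the methyl group on the new ring. From the compounds shown here alone, how a pyrazole without that methyl group, a pyridine ring or an amine would read at this position also remains open.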